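Nucleoside nitrile to thioamide: an untested change

The source may hold more compounds than are shown below. What is called first, only, known or untested is meant among the compounds shown, and "the series" means these compounds.

Two nucleosides of the same fused core have been measured in a functional assay on KB cells (Homo sapiens) for inhibition; on this read-out lower numbers stand for stronger inhibition and higher numbers for weaker inhibition. Compound 1 `N#Cc1cn([C@H]2C[C@H](O)[C@@H](CO)O2)c2ncnc(N)c12` gives 25000 nM. Compound 2 `N#Cc1cn([C@@H]2O[C@H](CO)[C@@H](O)[C@@H]2N)c2ncnc(N)c12` gives 105000 nM, and it stands as the higher of the two numbers, with a 4.2-fold higher number from compound 1 to compound 2 (0.62 log units; beyond the scatter). Compound 3 `N=C(S)c1cn([C@@H]2O[C@H](CO)[C@@H](O)[C@@H]2N)c2ncnc(N)c12` is the new member: it differs from compound 2 by a group of 3 heavy atoms (1 carbon, 1 nitrogen, 1 sulfur; no ring) in place of a group of 2 heavy atoms (1 carbon, 1 nitrogen; no ring), on an aromatic carbon. Among the measured compounds shown here, the one measured step, from compound 1 to compound 2, changes a saturated ring carbon and says nothing about the group on the aromatic carbon, so no measured step bears on the present change. Without such a precedent the expected step is a 1.1-fold lower number from compound 2 to compound 3 (0.02 log units; within the scatter), that is, no change beyond the scatter. Compound 3 is therefore estimated at 100000 nM in this assay, within a range from 30000 nM to 330000 nM.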

Compound 3, half-maximal inhibitory concentration: 2500 nM
The estimate for compound 3 lay 40-fold (1.60 log units) above the measured number; the whole stated range lies above it.
By their numbers in this assay, from the lowest: compound 3; then compound 1; then compound 2.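

In this assay, the group on this aromatic carbon of the five-membered ring proves to be a strong lever on the number: replacing cyano with the group of carbon, nitrogen and sulfur gives a 42-fold lower number from compound 2 to compound 3 (1.62 log units; beyond the scatter) while the rest of the molecule stays the same. The earlier step, a 4.2-fold higher number from compound 1 to compound 2 (0.62 log units; beyond the scatter), concerned only a saturated ring carbon and could not reveal this. The data shown offer no measurement that explains the size of the new step.

From the compounds shown here alone, it remains open whether sulfur itself matters, which a carboxamide, with oxygen in place of sulfur, or a carboxylic acid on the same aromatic carbon could help to test. Also open, going by these compounds, is whether the same replacement has a similar effect on compound 1, which carries hydrogen rather than amino on the saturated ring carbon.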